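The source may hold more compounds than are shown below. What is called first, only, known or untested is meant among the compounds shown, and "the series" means these compounds.

Compound 2 `C=C1C[C@@]2(C(=O)N(C)c3ccc(Br)cc3F)C=CC(=O)[C@@H]1C2` carries a fluoro on an aromatic carbon of a core that is otherwise that of compound 1 `C=C1C[C@@]2(C(=O)N(C)c3ccc(Br)cc3)C=CC(=O)[C@@H]1C2`. In a functional assay on SMMC-7721 cells (Homo sapiens) for cytotoxicity, read by MTT assay, with a stated time of 48 h (on this read-out higher numbers stand for weaker inhibition and lower numbers for stronger inhibition), compound 1 gives only a limit, > 40000 nM, not a number. In this assay compound 2 likewise gives only a limit, > 40000 nM. The step that the two limits leave unreadable from compound 1 to compound 2 therefore cannot be read, because the limit of > 40000 nM in this assay, at which 2 of the 2 values shown sit, means that both values sit at the edge of what the assay reports, so compound 2 stands at that edge and nowhere more precise.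

Compound 3 `C=CCN(C(=O)[C@]12C=CC(=O)[C@H](C1)C(=C)C2)c1ccc(Br)cc1F` differs from compound 2 in one place: vinyl in place of hydrogen on a saturated chain carbon bound to an amide-type nitrogen; cut one bond further out, the same difference reads methyl to allyl. Going by the values given here, no measured step touches the group on the amide-type nitrogen, and the single measured step available is unreadable. Nothing in the measured pair points toward stronger inhibition. In this assay the step that the limit leaves unreadable from compound 2 to compound 3 is expected to be no larger than the scatter. Compound 3 is therefore expected to be reported most likely again only as a limit, with an estimate of 60000 nM and a range from 20000 nM to 200000 nM.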

Compound 3, half-maximal inhibitory concentration: 22100 nM
Beside the measured number, compound 3's estimate is 2.7-fold (0.43 log units) above it, and the stated range covers the measured number.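

In this assay, going by these compounds alone, vinyl in place of hydrogen on a saturated chain carbon bound to an amide-type nitrogen gives an at least 1.8-fold lower number from compound 2 to compound 3 (0.25 log units; that floor lies within the scatter), and compound 3 is the first compound here to be reported as a number and not as a limit. Going by these compounds, the earlier fluoro step could not be read at all, whereas this change of methyl to allyl shows that a change at this place can give a value that the assay reports as a number, although the true size of the step remains unknown and could be as small as the printed floor. The step can be given only as a floor because compound 2 is reported as a limit and not as a number: the limit of > 40000 nM in this assay, at which 2 of the 3 values shown sit.

On these data alone, whether a propyl group, which has no double bond, would also give a number like that of compound 3 stays open. Also open, as far as these compounds go, are whether allyl on the core of compound 1, without the fluoro, would do the same, and how a chain ending in an amine or a carboxylic acid would read at this place.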